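A Difluoromethyl Added to the Carbamate Tail

The compounds below may be only part of what the source reports. "The series", "measured", "known", "first", "only" and "open" are said of these compounds alone.

Three compounds share one core and differ in what hangs off it. In a functional assay on HEK293 cells for agonist activity at Glucose-dependent insulinotropic receptor (Homo sapiens), read by cAMP accumulation, with a stated time of 30 min (on this read-out higher numbers stand for an effect only at larger amounts of compound and lower numbers for an effect already at smaller amounts), compound 1 `CC(C)OC(=O)N1CCC(n2ncc3cc(-c4ccc(S(C)(=O)=O)cc4)ncc32)CC1` gives 42 nM. Compound 2 `CC(C)OC(=O)N1CCC(n2ncc3cc(-c4ccc(S(C)(=O)=O)cc4F)ncc32)CC1` gives 27 nM in this assay, and compound 3 `CC(C)OC(=O)N1CCC(n2ncc3cc(-c4ccc(C(N)=O)cc4F)ncc32)CC1` gives 97 nM. Compound 2 thus shows the lowest of the three numbers. The change a 1.6-fold lower number from compound 1 to compound 2 (0.19 log units; within the scatter) stays within the scatter, whereas a 3.6-fold higher number from compound 2 to compound 3 (0.56 log units; beyond the scatter) and a 2.3-fold higher number from compound 1 to compound 3 (0.36 log units; beyond the scatter) both reach beyond it.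

Compound 4 `CC(C)(OC(=O)N1CCC(n2ncc3cc(-c4ccc(S(C)(=O)=O)cc4F)ncc32)CC1)C(F)F` differs from compound 2 by difluoromethyl in place of hydrogen on a saturated chain carbon bound to an oxygen next to a carbonyl group and two saturated chain carbons. Every measured step concerns the aromatic group, either the fluoro or the swap of methylsulfonyl for carbamoyl; none of them touches the carbamate end where the new group enters. Going by the values given here, no measured step therefore bears on this change, and there is nothing to point up or down. The expected outcome for compound 4 is no change at the digits printed from compound 2 to compound 4 (within the scatter), a step within the scatter. Compound 4 is estimated at 27 nM, within a range from 9 nM to 80 nM.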

Compound 4, half-maximal effective concentration: 10 nM
Compound 4: the middle estimate sits 2.7-fold (0.43 log units) above what was measured; low and high end bracket the measured number.
By their numbers in this assay, from the lowest: compound 4; then compounds 2 and 1 (each within the scatter of the next); then compound 3.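

The carbamate tail is not a silent part of the molecule: turning isopropyl into 1-(difluoromethyl)-1-methylethyl gives a 2.7-fold lower number from compound 2 to compound 4 (0.43 log units; beyond the scatter). Going by these compounds alone, every earlier step concerned the aromatic group, so this is the first sign that the number in this assay also responds to a change at the far end, here towards an effect at smaller amounts of compound. Nothing at hand speaks to why the number moves with this change.

What a plain methyl or a trifluoromethyl would do in place of the difluoromethyl on the same saturated chain carbon remains open, so the compounds shown cannot say whether the fluorines matter. Also open, on these data alone, is whether the new tail gives a similar step when carbamoyl stands in place of methylsulfonyl on the aromatic group.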